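Pyrimidinyl-to-carbamoylpyridinyl exchange on the shared core: solubility outlook

This account rests on a few compounds, and the source may have more. Where it says the series, first, only, none or still open, it means among the compounds named here.

Measured compounds:
compound 1 `FC(F)(F)c1cccc(-c2nc3cnc(Nc4ncccn4)cc3[nH]2)c1`; in a physicochemical assay for solubility, using the shake flask method, in phosphate buffer, measured as kinetic solubility, with a stated time of 20 h, at pH 6.5 (on this read-out lower numbers stand for lower solubility and higher numbers for higher solubility), compound 1 gives < 5000 nM
compound 2 `Fc1ccc(-c2nc3cnc(Nc4cc(C(F)(F)F)ccn4)cc3[nH]2)cc1F`; in this assay compound 2 gives < 5000 nM
compound 3 `Fc1ccnc(Nc2cc3[nH]c(-c4ccc(F)c(F)c4)nc3cn2)c1`; in this assay compound 3 gives < 5000 nM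

Every value shown for this assay is a limit of the assay rather than a number. Compound 1 stands at that limit, < 5000 nM. Compound 2 also sits at the limit, < 5000 nM. Compound 3 likewise sits at the limit, < 5000 nM. Going by the values given here, the only step between two measured compounds that differ in one place, a step that the two limits leave unreadable from compound 2 to compound 3, is therefore unreadable, and the whole picture rests on (the limit of < 5000 nM in this assay, at which 3 of the 3 values shown sit).

Compound 4 `NC(=O)c1ccc(Nc2cc3[nH]c(-c4cccc(C(F)(F)F)c4)nc3cn2)nc1` differs from compound 1 by 5-carbamoylpyridin-2-yl in place of pyrimidin-2-yl on a nitrogen on an aromatic ring. Among the compounds with values here, no measured step touches this change, and the single measured step gives no size that could be carried over. The data thus offer no basis for a directional expectation in this assay beyond the scatter.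

Since compound 1 sits at < 5000 nM, compound 4 is expected to remain near that limit, an estimated 4000 nM (range 800 nM to 20000 nM).

The step that this estimate implies, a step that the limit leaves unreadable from compound 1 to compound 4, is itself expected to be unreadable against a limit.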

Compound 4, solubility: < 5000 nM
Compound 4 gave a limit, no number (the forecaster's own chance of this, stated with the estimate: 60%); the middle value does not contradict the limit.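

In this assay compound 1 and compound 4 both give only a limit, so the step between these two compounds cannot be read: the limit of < 5000 nM in this assay, at which 4 of the 4 values shown sit.

The compounds shown leave open where any of them lies relative to that limit, and whether 5-carbamoylpyridin-2-yl in place of pyrimidin-2-yl changes the read-out at all.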